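Swapping the boronic acid bearing group on a sulfonamide nitrogen

The source may hold more compounds than are shown below. What is called first, only, known or untested is meant among the compounds shown, and "the series" means these compounds.

Of the compounds shown here, three share one core and have been measured in an ADME assay on the whole organism (Rattus norvegicus) for pharmacokinetics, read by LC-MS, at a dose of 5 mg/kg by the oral route; a lower number here means less compound in the circulation, a higher number more compound in the circulation at the dose given. Compound 1 `CNC(=O)c1c(-c2ccc(F)cc2)oc2cc(N(Cc3ccc(B(O)O)c(F)c3)S(C)(=O)=O)c(C3CC3)cc12` gives 700 ng.h/mL in this assay. Compound 2 `CNC(=O)c1c(-c2ccc(F)cc2)oc2cc(N(c3ccc(B(O)O)c(Cl)c3)S(C)(=O)=O)c(C3CC3)cc12` gives 4800 ng.h/mL, and compound 3 `CNC(=O)c1c(-c2ccc(F)cc2)oc2cc(-n3ncnc3-c3ccc(B(O)O)c(F)c3)c(C3CC3)cc12` gives 7600 ng.h/mL. Within the data shown here, compound 2 thus stands second highest of the three; its value and that of compound 3 lie within the usual scatter of each other, while the only single-point step that reaches it, a 6.9-fold higher number from compound 1 to compound 2 (0.84 log units; beyond the scatter), is beyond the scatter and of modest size.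

Compound 4 `CNC(=O)c1c(-c2ccc(F)cc2)oc2cc(N(C3CCc4c(B(O)O)cccc43)S(C)(=O)=O)c(C3CC3)cc12` differs from compound 2 by a group of 12 heavy atoms (9 carbon, 1 boron, 2 oxygen; one five-membered non-aromatic ring of carbon only, one six-membered aromatic ring of carbon only) in place of a group of 10 heavy atoms (6 carbon, 1 boron, 2 oxygen, 1 chlorine; one six-membered aromatic ring of carbon only), on a sulfonamide nitrogen. Among the measured compounds shown here, only the step of a 6.9-fold higher number from compound 1 to compound 2 (0.84 log units; beyond the scatter) touches the same sulfonamide nitrogen, and it shows that exchanging the group there can shift this assay noticeably. Compound 3 changes a different part and carries no listed step. The direction for compound 4 is therefore uncertain, and a step of about a 2.4-fold lower number from compound 2 to compound 4 (0.38 log units; beyond the scatter) is expected. Compound 4 is estimated at 2000 ng.h/mL, with a range from 500 ng.h/mL to 6500 ng.h/mL.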

Compound 4, area under the concentration-time curve: 40 ng.h/mL
The estimate for compound 4 lay 50-fold (1.70 log units) above the measured number; measured number outside the range, below it.
By their numbers in this assay, from the lowest: compound 4; then compound 1; then compounds 2 and 3 (each within the scatter of the next).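

In this assay this sulfonamide nitrogen turns out to allow a steep fall as well as a rise, with a 120-fold lower number from compound 2 to compound 4 (2.08 log units; beyond the scatter) and an 18-fold lower number from compound 1 to compound 4 (1.24 log units; beyond the scatter) on exchanging the group there. Both steps are large and point the same way, so the group with the five-membered non-aromatic ring gives the lowest number of the three compounds that carry a group on this nitrogen. Nothing measured here accounts for the fall.

The exchange alters several things at once, since the five-membered non-aromatic ring enters while the chlorine leaves, and the compounds shown cannot say which of these carries the fall. Also open, from the compounds shown here alone, is how a much simpler group on the same nitrogen, such as an ethyl chain, would read, or a ring with a carboxylic acid in place of the boronic acid.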